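The compounds below may be only part of what the source reports. "The series", "measured", "known", "first", "only" and "open" are said of these compounds alone.

Measured in an ADME assay on MT4 cells (Homo sapiens) for cytotoxicity, read by MTT assay, with a stated time of 3 days (a higher number here means that more compound is tolerated, a lower number that less compound is tolerated), each value a limit:
- compound 1 `CC(C)(C)NC(=O)COC(=O)c1ccc([N+](=O)[O-])o1`: > 100000 nM
- compound 2 `CCC(C)(C)NC(=O)COC(=O)c1ccc([N+](=O)[O-])o1`: > 100000 nM
- compound 3 `CC(C)(C)N(Cc1ccc([N+](=O)[O-])cc1)C(=O)COC(=O)c1ccc([N+](=O)[O-])o1`: > 100000 nM

Compound 3 gives only a limit, > 100000 nM, and no number. Among the measured compounds shown here, the series so far is described by the limit of > 100000 nM in this assay, at which 3 of the 3 values shown sit. Compound 4 `CC(C)(C)N(Cc1ccccc1C(F)(F)F)C(=O)COC(=O)c1ccc([N+](=O)[O-])o1` differs from compound 3 as follows: 2-(trifluoromethyl)phenyl in place of 4-nitrophenyl on a saturated chain carbon bound to an amide-type nitrogen. For the measured compounds named here, the one measured step, a step that the two limits leave unreadable from compound 1 to compound 2, lies elsewhere in the molecule and gives no size to carry over. With compound 3 as the reference at > 100000 nM, no step beyond the scatter is expected in this assay. The estimated change is a number no higher from compound 3 to compound 4 (the limit leaves the size open). Compound 4 is expected at 100000 nM, with an estimated range of 40000 nM to 200000 nM.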

Compound 4, half-maximal cytotoxic concentration: 95000 nM
Compound 4: the middle estimate sits 1.1-fold (0.02 log units) above what was measured; low and high end bracket the measured number.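

In this assay, among the compounds shown here, compound 4 gives 95000 nM, the only value shown that is a number and not a limit. With 2-(trifluoromethyl)phenyl in place of 4-nitrophenyl on a saturated chain carbon bound to an amide-type nitrogen, the result is an at least 1.0-fold lower number from compound 3 to compound 4 (0.02 log units; that floor lies within the scatter), so this change shows no step beyond the scatter. The rest of the series stays at a limit: the limit of > 100000 nM in this assay, at which 3 of the 4 values shown sit.

Still open, on these data alone, is whether an amine or a carboxylic acid at this place would give a clear step in this assay. Also open, as far as these compounds go, is how far the number moves with changes elsewhere on the shared core.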